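The compounds below may be only part of what the source reports. "The series", "measured", "known", "first", "only" and "open" are said of these compounds alone.

For the measured compounds named here, in an ADME assay on MDCKII-LE cells (Canis lupus familiaris) for permeability (a higher number here means that the compound crosses the layer faster, a lower number that the compound crosses the layer more slowly), compound 1 (`O=C(O)c1ccc(NC(=O)[C@H](CC2CCCC2)n2cnc(C(F)(F)F)c2)nc1`) gives 1 10^-6 cm/s and this is the only number available. Compound 2 (`O=C(O)Cn1ccc(NC(=O)[C@H](CC2CCCC2)n2cnc(C(F)(F)F)c2)n1`) has no place on that scale: its entry reads "not determined" (no result reported) and it therefore offers no measured starting point. The step to compound 3 (`O=C(O)c1cnc(NC(=O)[C@H](CC2CCCC2)n2cnc(C(F)(F)F)c2)cn1`) puts 5-carboxypyrazin-2-yl in place of 1-(carboxymethyl)-1H-pyrazol-3-yl on an amide-type nitrogen. The two groups match in the counted heavy atoms, and the difference lies in the ring and in the carboxymethyl link that leaves. Going by the values given here, no measured pair shows what a change of this kind does in this assay and no step from compound 2 can be sized. No direction is therefore expected for this step. The expectation rests instead on compound 1 at 1 10^-6 cm/s as the sole reference, with a result for compound 3 anticipated within the usual scatter of that value, or only slightly lower. For compound 3 the expected value is 0.8 10^-6 cm/s within an estimated range from 0.3 10^-6 cm/s to 2 10^-6 cm/s in this measurement.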

Compound 3, apparent permeability: 1.1 10^-6 cm/s
Beside the measured number, compound 3's estimate is 1.4-fold (0.14 log units) below it; measured number inside the range.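

In this assay the series now has its first readable pair on the amide-type nitrogen, and it gives a 1.1-fold higher number from compound 1 to compound 3 (0.04 log units; within the scatter) when 5-carboxypyrazin-2-yl stands in place of 5-carboxypyridin-2-yl. The two groups therefore cannot be told apart in this read-out, so this one exchange of six-membered aromatic rings, each with a carboxylic acid, leaves the number within the scatter; the step that starts from compound 2 cannot be read, so the exchange of 1-(carboxymethyl)-1H-pyrazol-3-yl for 5-carboxypyrazin-2-yl remains unsized. Nothing measured alongside this result explains why the number holds across the pair.

The compounds shown leave open whether any group at this place without a carboxylic acid, such as a methyl ester or a primary amide in its stead, would give a step beyond the scatter. They also leave open whether a change elsewhere on the shared core, for instance a longer chain in place of the cyclopentylmethyl group, would move the number at all.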